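Cytotoxicity of two thiazole amides and a planned third

A few compounds are considered here, and "the series" means these few. Any claim that something is new, unique, unknown or untested is made for them only; others in the source may bear on it.

Measured so far:
compound 1 `CC(C)(C)OC(=O)Nc1ncc(C(Oc2cccc(C#N)c2)c2ccc(Cl)cc2)s1` — > 50000 nM
compound 2 `O=C(Nc1ncc(C(Oc2ccc3cc(Br)ccc3c2)c2ccc(Cl)cc2)s1)c1cccs1` — "not toxic" (no number reported)

In an ADME assay on HepG2 2.2.15 cells (Homo sapiens) for cytotoxicity (on this read-out lower numbers stand for higher toxicity in this test and higher numbers for lower toxicity in this test), compound 1 gives > 50000 nM, which is a limit of the measurement rather than a number. Compound 2 is reported in this assay as "not toxic" (no number reported), with no figure attached. Compound 2 therefore stands without a single number; the only numerical anchor in this set is the limit of > 50000 nM in this assay, at which 1 of the 2 values shown sits, and both values point the same way, towards weak toxicity in this test.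

Compound 3 `O=C(Nc1ncc(C(Oc2ccc3cc(Br)ccc3c2)c2ccc(Cl)cc2)s1)c1ccc(F)cc1Br` is the next compound to be measured in this assay. It differs from compound 2 in one place: 2-bromo-4-fluorophenyl in place of thiophen-2-yl on a carbonyl carbon.

For the measured compounds named here, no step between measured compounds is available, so the size of the step from compound 2 to compound 3 in this assay cannot be read from data. Given that compound 2 shows "not toxic" (no number reported), the expectation is no step beyond the scatter in either direction. For compound 3 in this assay the estimated value is 50000 nM, expected to fall between 20000 nM and 100000 nM, most likely again reported only as a limit.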

Compound 3, half-maximal cytotoxic concentration: > 50000 nM
Compound 3: only a limit was reported; the forecaster's own chance of this, stated with the estimate: 70%; the middle value lies on the limit itself.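

In this assay compound 3 gives > 50000 nM, which is a limit and not a number. For the compounds shown here, compound 2 is reported as "not toxic" (no number reported), so no step from compound 2 to compound 3 can be read. The compounds shown leave open whether 2-bromo-4-fluorophenyl in place of thiophen-2-yl shifts this read-out at all.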